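The source may report more compounds than this note shows. Statements on the series, on what has been measured and on what is new or still open speak of the compounds shown alone.

Compounds measured so far:
Compound 1 `O=C(Nc1ccc(S(=O)(=O)NCc2ccccc2)cc1)c1ccc(Cl)cc1Cl` — in a functional assay on HEK293 cells for agonist activity at probable G-protein coupled receptor 27 (Homo sapiens), read by a luciferase reporter and beta-arrestin recruitment, with a stated time of 10 min (a higher number here means that more compound is needed for the effect, a lower number that less compound is needed), compound 1 gives a limit of the assay, > 100000 nM.
Compound 2 `COc1ccc(NS(=O)(=O)c2ccc(NC(=O)c3ccc(Cl)cc3Cl)cc2)cc1` — in this assay compound 2 likewise gives only a limit, > 100000 nM.
Compound 3 `O=C(Nc1ccc(S(=O)(=O)Nc2ccccc2)cc1)c1ccc(Cl)cc1Br` — in this assay compound 3 gives 1020 nM.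

Compound 3 is therefore the only one of the three that yields a number; the other two sit at the limit, as noted in the limit of > 100000 nM in this assay, at which 2 of the 3 values shown sit. Among the measured compounds shown here, the one step with two measured ends, a step that the two limits leave unreadable from compound 1 to compound 2, cannot be read in size, since both of its ends are limits, and it concerns the sulfonamide nitrogen rather than the acyl ring.

Compound 4 `O=C(Nc1ccc(S(=O)(=O)Nc2ccccc2)cc1)c1ccc(Cl)cc1Cl` differs from compound 3 in one place: chloro in place of bromo on an aromatic carbon. For the measured compounds named here, no measured step touches this exchange, so nothing in the data sets its size or direction. Compounds 1 and 2, which also carry the 2,4-dichlorophenyl group but with a different substituent on the sulfonamide nitrogen, give only limits and so offer no guide to the halogen exchange itself. The expected step from compound 3 to compound 4 is estimated as a 1.5-fold higher number from compound 3 to compound 4 (0.17 log units; within the scatter), within the scatter. Compound 4 is accordingly expected to give about 1500 nM in this assay, with a likely range from 500 nM to 5000 nM.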

Compound 4, half-maximal effective concentration: 457 nM
For compound 4 the middle estimate is 3.3-fold (0.52 log units) above the measured one, and the stated range ends above it.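

Among the compounds shown here, the exchange of bromo for chloro on the aromatic carbon ortho to a large group gives the first step at this place that can be read in size: in this assay there is a 2.2-fold lower number from compound 3 to compound 4 (0.35 log units; beyond the scatter), so this halogen position responds measurably to the change from 2-bromo-4-chlorophenyl to 2,4-dichlorophenyl. Compound 4 also shows that the 2,4-dichlorophenyl group can carry a measured value, and that the change on the other side of the shared core counts for far more, with an at least 210-fold lower number from compound 1 to compound 4 (2.34 log units; beyond the scatter) for phenyl in place of benzyl on the sulfonamide nitrogen and an at least 210-fold lower number from compound 2 to compound 4 (2.34 log units; beyond the scatter) for hydrogen in place of methoxy on the aromatic carbon. These two larger steps each start from a limit of the assay and so give only a minimum size: the limit of > 100000 nM in this assay, at which 2 of the 4 values shown sit.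

What the compounds shown leave open is how fluoro, methyl or hydrogen would compare with chloro and bromo at this position. They also leave open how a methyl group or a longer chain on the sulfonamide nitrogen would compare with phenyl and benzyl.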